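From (3,4-dimethylphenyl)amino to benzylamino on a shared core

A few compounds are considered here, and "the series" means these few. Any claim that something is new, unique, unknown or untested is made for them only; others in the source may bear on it.

In a functional assay on ECa-109 cells for inhibition, with ECa-109 cell line (Homo sapiens) as the target, read by sulforhodamine B assay (on this read-out higher numbers stand for weaker inhibition and lower numbers for stronger inhibition), compound 2 `Cc1ccc(NC2=CC(=O)c3c(nc4n3[C@H]3OC[C@@H](O)[C@H]3OC4)C2=O)cc1C` gives 4090 nM, the larger of the two numbers on record, though the gap to compound 1 `Cc1ccc(NC2=CC(=O)c3nc4n(c3C2=O)[C@H]2OC[C@@H](O)[C@H]2OC4)cc1C` at 2820 nM lies within the scatter. Compound 3 `O=C1C=C(N2CCCCC2)C(=O)c2c1nc1n2[C@H]2OC[C@@H](O)[C@H]2OC1` reaches only the assay limit, > 8000 nM. Compound 4 `O=C1C(NCc2ccccc2)=CC(=O)c2c1nc1n2[C@H]2OC[C@@H](O)[C@H]2OC1` has not yet been measured; it differs from compound 2 by benzyl in place of 3,4-dimethylphenyl on an amine nitrogen. Going by the values given here, the one measured step of a related kind, an at least 2.8-fold higher number from compound 1 to compound 3 (0.45 log units; beyond the scatter), removed the (3,4-dimethylphenyl)amino group entirely and weakened inhibition as far as the limit of > 8000 nM in this assay, at which 1 of the 3 values shown sits. Compound 4 keeps an amine hydrogen but loses the aromatic ring on the amine nitrogen, so a modest weakening is expected, a 1.5-fold higher number from compound 2 to compound 4 (0.17 log units; within the scatter). Compound 4 is therefore estimated at 6000 nM, with a likely range from 3000 nM to 12000 nM.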

Compound 4, half-maximal inhibitory concentration: > 8000 nM
Compound 4 gave a limit, no number; the forecaster's own chance of this, stated with the estimate: 30%; middle value at least 1.3-fold (0.12 log units) away from the limit.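

In this assay, benzyl in place of 3,4-dimethylphenyl gives an at least 1.9-fold higher number from compound 2 to compound 4 (0.29 log units; that floor lies within the scatter), so the step may be small or much larger. Keeping both the amine hydrogen and a six-membered aromatic ring on this nitrogen therefore did not keep compound 4 on the measurable scale. Its value is only a limit, and such limits now make up more of the series: the limit of > 8000 nM in this assay, at which 2 of the 4 values shown sit.

Going by these compounds, how far beyond the limit compound 4 truly lies stays open. So does what a phenethyl group or a methyl group on this amine nitrogen would give.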